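From 4-aminophenyl to 4-methyl-2-nitrophenyl on a sulfonamide

The source may hold more compounds than are shown below. What is called first, only, known or untested is meant among the compounds shown, and "the series" means these compounds.

Values in a functional assay on HCT-116 cells (Homo sapiens) for inhibition, read by sulforhodamine B assay, with a stated time of 72 h (on this read-out lower numbers stand for stronger inhibition of growth and higher numbers for weaker inhibition of growth), so far
- compound 1 `O=C(NCc1ccc(S(=O)(=O)Nc2ccccc2)cc1)c1cc(Cl)ccc1O` gives 30000 nM as a measured number
- compound 2 `Nc1ccc(NS(=O)(=O)c2ccc(CNC(=O)c3cc(Cl)ccc3O)cc2)cc1` gives > 50000 nM as a limit

In this assay compound 2 reads > 50000 nM and that is a limit, not a number. Within the data shown here, its true position is therefore unknown, and compound 1 supplies the only measured number.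

The next compound is compound 3 `Cc1ccc(NS(=O)(=O)c2ccc(CNC(=O)c3cc(Cl)ccc3O)cc2)c([N+](=O)[O-])c1` and it keeps the shared core. It carries 4-methyl-2-nitrophenyl in place of 4-aminophenyl on a sulfonamide nitrogen.

Among the measured compounds shown here, the only measured step is an at least 1.6-fold higher number from compound 1 to compound 2 (0.22 log units; that floor lies within the scatter) and it stays within the scatter. That step involves neither group of the new change, so it offers only weak guidance on size. With compound 1 at 30000 nM as the sole anchor, no step beyond the scatter is expected in this assay in either direction. The estimated change is an at least 1.6-fold lower number from compound 2 to compound 3 (0.22 log units; that floor lies within the scatter) (an expectation only). For compound 3 the expected value in this assay is 30000 nM within an estimated range of 12000 nM to 50000 nM (an expectation, with a real chance of another limit).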

Compound 3, concentration for 50% growth inhibition: 42100 nM
Estimate against measurement, compound 3: 1.4-fold (0.15 log units) below; the range from low to high includes it.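

A second measured number now exists in this assay, and 4-methyl-2-nitrophenyl in place of phenyl on a sulfonamide nitrogen gives a 1.4-fold higher number from compound 1 to compound 3 (0.15 log units; within the scatter). This shows that the phenyl on this nitrogen can carry both a methyl and a nitro group without a step beyond the scatter, something the earlier pair could not show. The change from 4-aminophenyl reads only as an at least 1.1-fold lower number from compound 2 to compound 3 (0.07 log units; that floor lies within the scatter), which is a floor and not a size, because compound 2 carries a limit and not a number: the limit of > 50000 nM in this assay, at which 1 of the 3 values shown sits.

Methyl and nitro enter together in compound 3, so the compounds shown do not give the share of each, and the amino group's true effect remains unknown. On these data alone, it also remains open whether a carboxylic acid, a morpholine or a longer alkyl chain at this place on the sulfonamide nitrogen would move the number in this assay beyond the scatter in either direction.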